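Swapping a halogen on a bis-aryl amidine growth inhibitor

The compounds below may be only part of what the source reports. "The series", "measured", "known", "first", "only" and "open" are said of these compounds alone.

Measured compounds:
compound 1 `N=C(N)c1ccc(-c2ccc(-c3cc(Cl)cc(Cl)c3)s2)s1`, 1750 nM
compound 2 `N=C(N)c1ccc(-c2ccc(-c3ccc(Cl)cc3)o2)o1`, 1500 nM
compound 3 `N=C(N)c1ccc(-c2ccc(-c3ccc4ccccc4c3)s2)s1`, 2460 nM

In a functional assay on EKVX cells (Homo sapiens) for inhibition, read by sulforhodamine B assay, with a stated time of 48 h (on this read-out higher numbers stand for weaker inhibition of growth and lower numbers for stronger inhibition of growth), compound 2 gives 1500 nM. Compound 1 gives 1750 nM and compound 3 gives 2460 nM; both of these sit within the usual scatter of compound 2, so the three measured compounds are not separated from one another by this read-out.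

Compound 4 `N=C(N)c1ccc(-c2ccc(-c3ccc(F)cc3)o2)o1` has not yet been measured. It differs from compound 2 in one place: fluoro in place of chloro on an aromatic carbon.

Going by the values given here, no step between two measured compounds bears on this change, so there is no direct guide from the data. The change is small, and the expectation is a step of a 1.3-fold higher number from compound 2 to compound 4 (0.12 log units; within the scatter) that does not clearly exceed the scatter, if anything toward a slightly higher number. Compound 4 is therefore estimated at 2000 nM in this assay, with a range from 800 nM to 5000 nM.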

Compound 4, concentration for 50% growth inhibition: 1350 nM
For compound 4 the middle estimate is 1.5-fold (0.17 log units) above the measured one, and the stated range covers the measured number.
By their numbers in this assay, from the lowest: compounds 4, 2, 1 and 3 (each within the scatter of the next).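

In this assay, fluoro in place of chloro on an aromatic carbon, para to a large group, gives a 1.1-fold lower number from compound 2 to compound 4 (0.05 log units; within the scatter) and so leaves the growth inhibition within the scatter. Going by these compounds alone, this is the first one-place step among the compounds, and it shows that this halogen swap does not separate the pair. Nothing measured here offers an explanation for this result. On these data alone, it remains open whether an amine or a carboxylic acid at this place would leave the read-out similarly unchanged, and whether removing the halogen altogether, leaving hydrogen, would do the same.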